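The source may hold more compounds than are shown below. What is called first, only, known or untested is meant among the compounds shown, and "the series" means these compounds.

Measured so far:
compound 1 `O=c1cc(CCc2ccccc2)c2ccc(O)cc2o1`: 20 nM
compound 2 `O=c1cc(COc2ccccc2)c2ccc(O)cc2o1`: 10000 nM
compound 3 `O=c1cc(CNc2ccccc2)c2ccc(O)cc2o1`: 4000 nM

In an assay on HeLa cells for inhibition of 17-beta-hydroxysteroid dehydrogenase type 3 (Homo sapiens) (a lower number here means a stronger inhibitor, a higher number a weaker inhibitor), compound 1 gives 20 nM, compound 2 gives 10000 nM and compound 3 gives 4000 nM. Compound 3 therefore stands second highest of the three numbers: compound 2 is nearest, and compound 1 is furthest with a far lower number. The unmeasured compound 4 `CN(Cc1cc(=O)oc2cc(O)ccc12)c1ccccc1` differs from compound 3 by methyl in place of hydrogen on a nitrogen on an aromatic ring. Among the compounds with values here, no measured pair shows this change, so nothing here tells how it acts in this assay. Compound 4 is expected to stay close to compound 3, with a step of a 1.3-fold lower number from compound 3 to compound 4 (0.12 log units; within the scatter) that may well lie within the scatter. The estimate for compound 4 is 3000 nM, within 800 nM to 12000 nM.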

Compound 4, half-maximal inhibitory concentration: 6000 nM
The estimate for compound 4 lay 2.0-fold (0.30 log units) below the measured number; the range from low to high includes it.
By their numbers in this assay, from the lowest: compound 1; then compounds 3, 4 and 2 (each within the scatter of the next, the first and the last beyond it).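

In this assay, within the data shown here, methyl in place of hydrogen on the nitrogen gives a 1.5-fold higher number from compound 3 to compound 4 (0.18 log units; within the scatter), the first reading of any change at this nitrogen. The hydrogen there can therefore be exchanged for methyl without a shift beyond the scatter, and compound 4 stays in the same range as compound 3. Nothing at hand gives a reason for this result. Still open, going by these compounds, is whether a longer chain such as ethyl, or an acetyl group, on this nitrogen would also leave the number in this range. Whether methyl behaves the same way on the linking chain of compound 1 is open too.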